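A few compounds are considered here, and "the series" means these few. Any claim that something is new, unique, unknown or untested is made for them only; others in the source may bear on it.

In a functional assay on HeLa cells (Homo sapiens) for antiproliferative activity, with a stated time of 24 h (on this read-out higher numbers stand for weaker inhibition and lower numbers for stronger inhibition), compound 1 `NC(=O)c1c(NC(=O)c2ccc(C(F)(F)F)cc2)sc2c1CCN(C(=O)Nc1ccccc1Cl)C2` gives only a limit of the assay, > 50000 nM. Compound 2 `Cc1ccc(C(=O)Nc2sc3c(c2C(N)=O)CCN(C(=O)Nc2ccccc2Cl)C3)cc1` differs from it by methyl in place of trifluoromethyl on an aromatic carbon and in this assay gives 32900 nM. Across that pair the change made an at least 1.5-fold lower number from compound 1 to compound 2 (0.18 log units; that floor lies within the scatter), a step read against (the limit of > 50000 nM in this assay, at which 1 of the 3 values shown sits). Compound 3 `NC(=O)c1c(NC(=O)c2ccccc2Br)sc2c1CCN(C(=S)Nc1ccccc1C(F)(F)F)C2` rests on a second core, and the difference between the two cores is not broken down here. In this assay compound 3 gives 39600 nM, a number that sits within the scatter of compound 2. Compound 4 `Cc1ccccc1NC(=S)N1CCc2c(sc(NC(=O)c3ccccc3Br)c2C(N)=O)C1` has not yet been measured; it differs from compound 3 by methyl in place of trifluoromethyl on an aromatic carbon. The surroundings of the place are not the same word for word: in the first pair the group sits para to a large group, in the second it sits ortho to a large group, so this is the same kind of change rather than the same change. Compound 4 is expected to show a 1.3-fold lower number from compound 3 to compound 4 (0.12 log units; within the scatter), a step of the same modest size as the earlier one an at least 1.5-fold lower number from compound 1 to compound 2 (0.18 log units; that floor lies within the scatter). Compound 4 is thus estimated at 30000 nM, between 12000 nM and 80000 nM.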

Compound 4, half-maximal inhibitory concentration: > 50000 nM
Compound 4 gave a limit, no number (the forecaster's own chance of this, stated with the estimate: 25%); at least 1.6-fold (0.22 log units) between middle value and limit.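

Compound 4 gives only a limit of the assay, > 50000 nM. Read against that limit, the new step is an at least 1.2-fold higher number from compound 3 to compound 4 (0.10 log units; that floor lies within the scatter), so methyl in place of trifluoromethyl can be compared across the two cores in this assay only through two floors: the same change on two cores in this assay, an at least 1.5-fold lower number (0.18 log units; that floor lies within the scatter) from compound 1 to compound 2 and an at least 1.2-fold higher number (0.10 log units; that floor lies within the scatter) from compound 3 to compound 4; the limit leaves it open whether they differ This shows neither that the change carries over from one core to the other with the same size or direction nor that it fails to carry over, and the comparison rests on values of which half are limits rather than numbers: the limit of > 50000 nM in this assay, at which 2 of the 4 values shown sit.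

The compounds shown leave open how an amine, a carboxylic acid or a methoxy group would read at this place in this assay, on either core. For the compounds shown here, they also contain no pair that differs only between the two cores, so the contribution of that difference to these readings remains open, as does the true size of both steps.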